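A few compounds are considered here, and "the series" means these few. Any claim that something is new, unique, unknown or untested is made for them only; others in the source may bear on it.

Compound 1, with the structure `O=C(Nc1ccc(OC(F)F)cc1)c1cccc(/C=C2\CC(=O)N(c3ccccc3)C2=O)c1`, was examined in an ADME assay on NCM460 cells (Homo sapiens) for cytotoxicity, read by MTT assay, with a stated time of 72 h; on this read-out higher numbers stand for weaker inhibition and lower numbers for stronger inhibition. In this assay compound 1 gives only a limit of > 100000 nM, not a number. Two companions from the same series were examined alongside it. Compound 2, with the structure `CCOc1ccc(NC(=O)c2cccc(/C=C3\CC(=O)N(Cc4ccccc4)C3=O)c2)cc1`, also reaches only a limit in this assay, at > 100000 nM. Compound 3, with the structure `CCCCCN1C(=O)C/C(=C\c2cccc(C(=O)Nc3ccc(OC)cc3)c2)C1=O`, likewise gives a limit of > 100000 nM in this assay. Every value gathered so far therefore stands at the limit of > 100000 nM in this assay, at which 3 of the 3 values shown sit, and no compound has yet shown a measurable number, so nothing can be said about how any change in structure shifts the read-out.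

The next compound, compound 4, has the structure `O=C(NCC1CCCCC1)c1cccc(/C=C2\CC(=O)N(c3ccccc3)C2=O)c1`. It differs from compound 1 in one place: cyclohexylmethyl in place of 4-(difluoromethoxy)phenyl on an amide-type nitrogen. Among the measured compounds shown here, no step between two measured compounds in this assay is available to build on. Because compound 1 and both of its companions sit at the limit of > 100000 nM in this assay, at which 3 of the 3 values shown sit, the expectation is that compound 4 remains at the limit as well. The expected step is therefore a step that the limit leaves unreadable from compound 1 to compound 4, which is none beyond the scatter. Compound 4 is estimated at 150000 nM, within a range from 50000 nM to 500000 nM, and most likely reported again only as a limit.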

Compound 4, half-maximal inhibitory concentration: > 100000 nM
Compound 4 ended at the assay's limit; the forecaster's own chance of this, stated with the estimate: 85%; the middle value lies beyond the limit too.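

In this assay compound 4 gives only a limit of > 100000 nM, not a number. Among the compounds shown here, compound 1 also stands at a limit, so no step from compound 1 to compound 4 can be read. The compounds shown leave open whether any structure in this series would give a measurable number in this assay: the limit of > 100000 nM in this assay, at which 4 of the 4 values shown sit.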